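The compounds below may be only part of what the source reports. "The series", "measured", "known", "first", "only" and "open" are said of these compounds alone.

Compound 1 `COc1ccc(OC)c(/C=C/C(=O)C(=Cc2ccc(O)c(OC)c2)C(=O)/C=C/c2cc(OC)ccc2OC)c1` and compound 2 `COc1ccc(OC)c(/C=C/C(=O)C(=Cc2ccc(O)c(F)c2)C(=O)/C=C/c2cc(OC)ccc2OC)c1` share one core and differ in a single place. In a functional assay on SW480 cells (Homo sapiens) for antiproliferative activity, read by sulforhodamine B assay, with a stated time of 48 h (a lower number here means a stronger inhibitor, a higher number a weaker inhibitor), compound 1 gives 410 nM, and compound 2 gives 510 nM. The change between them is fluoro in place of methoxy on an aromatic carbon, and it produced a 1.2-fold higher number from compound 1 to compound 2 (0.09 log units; within the scatter). Compound 3 `COc1ccc(/C=C/C(=O)C(=Cc2ccc(O)c(OC)c2)C(=O)/C=C/c2ccc(OC)cc2OC)c(OC)c1` is built from the same atoms as compound 1, joined differently; the difference between the two cores is not broken down here. In this assay compound 3 gives 1520 nM, the highest of the three numbers, and its gap to compound 2, its nearest neighbour, lies beyond the scatter. Compound 4 `COc1ccc(/C=C/C(=O)C(=Cc2ccc(O)c(F)c2)C(=O)/C=C/c2ccc(OC)cc2OC)c(OC)c1` has not yet been measured in this assay. It differs from compound 3 by fluoro in place of methoxy on an aromatic carbon, the same change that separates compound 1 from compound 2, made on the same kind of place. Because the earlier step was a 1.2-fold higher number from compound 1 to compound 2 (0.09 log units; within the scatter), the step expected here is a 1.2-fold higher number from compound 3 to compound 4 (0.06 log units; within the scatter), again within the scatter. Compound 4 is therefore estimated at 1750 nM in this assay, with a likely range from 900 nM to 3400 nM.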

Compound 4, half-maximal inhibitory concentration: 3350 nM
For compound 4 the middle estimate is 1.9-fold (0.28 log units) below the measured one, and the stated range covers the measured number.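

In this assay, replacing 4-hydroxy-3-methoxyphenyl with 3-fluoro-4-hydroxyphenyl on the core of compound 3 gave a 2.2-fold higher number from compound 3 to compound 4 (0.34 log units; beyond the scatter), a modest step. Set beside the same change on the core of compound 1, the two steps cannot be told apart, so the data are consistent with the change carrying over from one core to the other: the same change on two cores in this assay, a 1.2-fold higher number (0.09 log units; within the scatter) from compound 1 to compound 2 and a 2.2-fold higher number (0.34 log units; beyond the scatter) from compound 3 to compound 4, 1.8-fold (0.25 log units) apart, within the scatter of two such steps

Among the compounds shown here, this rests on only two pairs, however, and it does not show that the change would behave alike on other cores, nor does it explain why one step lies within the scatter and the other beyond it. The compounds shown carry only methoxy or fluoro at this place, so it remains open how chloro, methyl or an amine there would compare on these two cores. Also open, as far as these compounds go, is how the change would read if the hydroxy group on the same ring were exchanged for a carboxylic acid.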